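Replacing the Dimethoxyphenyl Group with a Thiophene Ring

The source may hold more compounds than are shown below. What is called first, only, known or untested is meant among the compounds shown, and "the series" means these compounds.

Measured so far:
- compound 1, `COc1ccc(-c2cc3ccccc3nc2/C=C/C(=O)c2ccc(F)cc2)cc1`, which in a functional assay on H184B5F5/M10 cells (Homo sapiens) for antiproliferative activity, read by XTT assay, with a stated time of 72 h (a higher number here means a weaker inhibitor, a lower number a stronger inhibitor), reaches only a limit of the assay, > 10000 nM.
- compound 2, `COc1ccc(-c2cc3ccccc3nc2/C=C/C(=O)c2ccc(OC)c(OC)c2)cc1`, which in this assay gives 7240 nM.

Among the compounds with values here, compound 2 holds the only actual number in this assay; the other value shown is a limit, (the limit of > 10000 nM in this assay, at which 1 of the 2 values shown sits). Within the data shown here, the single measured step, an at least 1.3-fold lower number from compound 1 to compound 2 (0.14 log units; that floor lies within the scatter), changes the group on the carbonyl carbon, but its floor lies within the scatter, so it settles neither size nor direction.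

Compound 3, `COc1ccc(-c2cc3ccccc3nc2/C=C/C(=O)c2cccs2)cc1`, differs from compound 2 at that same carbonyl carbon: thiophen-2-yl in place of 3,4-dimethoxyphenyl on a carbonyl carbon. Among the measured compounds shown here, because the only measured step at this position, an at least 1.3-fold lower number from compound 1 to compound 2 (0.14 log units; that floor lies within the scatter), is itself within the scatter, no shift beyond the scatter is expected from this exchange. Compound 3 is therefore estimated at 9000 nM, within 3000 nM to 30000 nM, meaning an expected step of a 1.2-fold higher number from compound 2 to compound 3 (0.09 log units; within the scatter).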

Compound 3, half-maximal inhibitory concentration: 7030 nM
The estimate for compound 3 lay 1.3-fold (0.11 log units) above the measured number, within the range that was stated.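

At the carbonyl carbon, two actual numbers in this assay can now be compared, and the step between them is readable (a 1.0-fold lower number from compound 2 to compound 3 (0.01 log units; within the scatter)). Thiophen-2-yl, with 5 heavy atoms and one five-membered aromatic ring, and 3,4-dimethoxyphenyl, with 10 heavy atoms and one six-membered aromatic ring, therefore cannot be told apart in this read-out, even though the exchange removes both oxygen atoms and brings in a sulfur atom. The other new step (an at least 1.4-fold lower number from compound 1 to compound 3 (0.15 log units; that floor lies within the scatter)) cannot be read for size or direction, as it rests on a limit of the assay: the limit of > 10000 nM in this assay, at which 1 of the 3 values shown sits.

On these data alone, whether an amine or a carboxylic acid on the ring at this carbonyl carbon would give a number clearly different from these stays open. The compounds shown also leave open what a change elsewhere on the shared core would do, such as replacing the methoxy group with a longer chain.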